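Two Hydrocarbon Groups Swapped, Acid Dissociation Expected Unchanged

The compounds below may be only part of what the source reports. "The series", "measured", "known", "first", "only" and "open" are said of these compounds alone.

Compound 1 `CCC(CC)c1ccc2c(NCCCNCc3cccc(OC)c3O)ccnc2c1` carries a pentan-3-yl group on an aromatic carbon of its core. In a physicochemical assay for acid dissociation, compound 1 gives 9.47. Two related compounds give the same reading: compound 2 `FC(F)(F)c1ccc(-c2ccc3c(NCCCNCc4ccco4)ccnc3c2)cc1` gives 9.47, and compound 3 `c1ccc(CCc2ccc3c(NCCCNCc4ccco4)ccnc3c2)cc1` gives 9.47. Going by the values given here, the one measured step between them, no change at the digits printed from compound 2 to compound 3 (within the scatter), shows that exchanging one group on an aromatic carbon for a rather different one left the reading where it was. Compound 1 thus stands level with compound 2 and compound 3 at the digits shown, and no compound among the three can be called higher or lower than another.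

Compound 4 `COc1cccc(CNCCCNc2ccnc3cc(CC4CCCCC4)ccc23)c1O` has not yet been measured. It differs from compound 1 in one place: cyclohexylmethyl in place of pentan-3-yl on an aromatic carbon. Both the leaving and the entering group are made of carbon only, with no hydrogen-bond donors or acceptors and no charge, and the change sits on an aromatic carbon of the core. Among the compounds with values here, the only measured step that bears on such a change, no change at the digits printed from compound 2 to compound 3 (within the scatter), moved the reading not at all beyond the scatter. Compound 4 is therefore expected to show essentially no change, no change at the digits printed from compound 1 to compound 4 (within the scatter). The estimate for compound 4 is 9.47, within a range from 9.2 to 9.75.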

Compound 4, acid dissociation constant: 9.47
The estimate for compound 4 equals the measured number at the digits printed; measured number inside the range.
By their numbers in this assay, from the lowest: compounds 1, 2, 3 and 4 (each within the scatter of the next).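

In this assay, putting cyclohexylmethyl in place of pentan-3-yl gives no change at the digits printed from compound 1 to compound 4 (within the scatter), so the flat result of no change at the digits printed from compound 2 to compound 3 (within the scatter) now has a second example at this position, on a compound whose other parts differ from those of compounds 2 and 3. The new pair also adds a different kind of exchange: a group with no ring, 5 heavy atoms in all, gives way to one with 7 heavy atoms and a six-membered non-aromatic ring of carbon only, and even this leaves the reading level. No supporting measurement is available to explain why the reading stays level in either pair.

On these data alone, what an amine or a carboxylic acid at this position would do to the reading remains open, since such a group would bring in atoms other than the carbon of the groups in compounds 1 and 4. The numbers also leave open which part of these molecules gives up the proton, and so how closely this position is connected to that part.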